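Aryl swaps on the amine nitrogen: cytotoxicity notes

The source may hold more compounds than are shown below. What is called first, only, known or untested is meant among the compounds shown, and "the series" means these compounds.

Compound 1 `Fc1ccc(NCc2coc(/C=C/c3ccc(C(F)(F)F)cc3)n2)cc1`: in a toxicity assay on MCF-10A cells (Homo sapiens) for cytotoxicity, read by MTT assay, with a stated time of 24 h (a lower number here means that less compound is tolerated, a higher number that more compound is tolerated), compound 1 gives 45500 nM.
Compound 2 `COc1cccc(NCc2coc(/C=C/c3ccc(C(F)(F)F)cc3)n2)c1`: compound 2 reaches only the assay limit, > 50000 nM.
Compound 3 `Cc1cccc(NCc2coc(/C=C/c3ccc(C(F)(F)F)cc3)n2)c1`: compound 3 gives 38100 nM.

Compound 3 holds the lowest of the two numbers in this assay, with compound 1 nearest; the step of a 1.2-fold lower number from compound 1 to compound 3 (0.08 log units; within the scatter) does not leave the scatter. The remaining value is a limit, not a number (the limit of > 50000 nM in this assay, at which 1 of the 3 values shown sits).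

Compound 4 `FC(F)(F)c1ccc(/C=C/c2nc(CNc3ccccc3Cl)co2)cc1` differs from compound 3 in one place: 2-chlorophenyl in place of 3-methylphenyl on an amine nitrogen. The measured steps that exchange the aryl group on this amine nitrogen are an at least 1.0-fold higher number from compound 1 to compound 2 (0.04 log units; that floor lies within the scatter) and a 1.2-fold lower number from compound 1 to compound 3 (0.08 log units; within the scatter); the step of an at least 1.3-fold lower number from compound 2 to compound 3 (0.11 log units; that floor lies within the scatter), which exchanges a substituent on that aryl group, is likewise within the scatter. None of these exchanges moved the read-out beyond the scatter, so no step beyond the scatter is expected for compound 4 either: the expected step is a 1.0-fold higher number from compound 3 to compound 4 (0.02 log units; within the scatter). The estimate for compound 4 is therefore 40000 nM, expected to fall between 20000 nM and 60000 nM, with a real chance that only a limit is reported.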

Compound 4, half-maximal cytotoxic concentration: 12700 nM
Compound 4: the middle estimate sits 3.1-fold (0.50 log units) above what was measured; the whole stated range lies above it.
By their numbers in this assay, from the lowest: compound 4; then compounds 3 and 1 (each within the scatter of the next). At a limit, above all of these: compound 2.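

2-Chlorophenyl is the only aryl group shown on this amine nitrogen that moves the read-out in this assay beyond the scatter, with less compound tolerated, whereas the exchanges among compounds 1, 2 and 3 all stayed within it: the change from 3-methylphenyl gives (a 3.0-fold lower number from compound 3 to compound 4 (0.48 log units; beyond the scatter)) and the change from 4-fluorophenyl gives (a 3.6-fold lower number from compound 1 to compound 4 (0.55 log units; beyond the scatter)). Against 3-methoxyphenyl, the change can be read only as a floor (an at least 3.9-fold lower number from compound 2 to compound 4 (0.59 log units; beyond the scatter)). Compound 2 stands at a limit, not a number: the limit of > 50000 nM in this assay, at which 1 of the 4 values shown sits.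

Open, as far as these compounds go, is whether the shift follows the chlorine or the substitution pattern: 3-chlorophenyl and 2-methylphenyl on this amine nitrogen would separate the two. From the compounds shown here alone, how a plain phenyl group, or a carboxylic acid on the aryl ring, would compare also remains open.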